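A 4-methylpiperazin-1-yl group on the shared core

This account rests on a few compounds, and the source may have more. Where it says the series, first, only, none or still open, it means among the compounds named here.

In a functional assay on SK-MEL-28 cells (Homo sapiens) for inhibition, read by MTT assay, with a stated time of 72 h (on this read-out lower numbers stand for stronger inhibition and higher numbers for weaker inhibition), compound 1 `C/C1=C\CC[C@@]2(C)O[C@@H]2[C@H]2OC(=O)[C@@H](CN3CCCC3)[C@@H]2C[C@H]1O` gives 19000 nM and compound 2 `C/C1=C\CC[C@@]2(C)O[C@@H]2[C@H]2OC(=O)[C@@H](CN3CCCCC3)[C@@H]2C[C@H]1O` gives 16000 nM on the same scale. Among the compounds with values here, compound 2 therefore stands level with the only other measured compound, as the two numbers lie within the scatter of each other.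

Compound 3 `C/C1=C\CC[C@@]2(C)O[C@@H]2[C@H]2OC(=O)[C@@H](CN3CCN(C)CC3)[C@@H]2C[C@H]1O` keeps the shared core and changes one group. The difference is 4-methylpiperazin-1-yl in place of piperidin-1-yl on a saturated chain carbon bound to a saturated ring carbon and it lies on a saturated chain carbon bound to a saturated ring carbon.

Within the data shown here, one measured step bears on this place: pyrrolidin-1-yl gave way to piperidin-1-yl in a 1.2-fold lower number from compound 1 to compound 2 (0.07 log units; within the scatter) and the number hardly moved. Among the measured compounds shown here, no measured compound carries a 4-methylpiperazin-1-yl group, so this guide is thin, and no step beyond the scatter is expected in this assay here.

The estimated change is a 1.1-fold higher number from compound 2 to compound 3 (0.03 log units; within the scatter) for this swap. For compound 3 the expected value is 17000 nM with an estimated range from 8000 nM to 36000 nM in this read-out.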

Compound 3, half-maximal inhibitory concentration: 57000 nM
Beside the measured number, compound 3's estimate is 3.4-fold (0.53 log units) below it; measured number outside the range, above it.
By their numbers in this assay, from the lowest: compounds 2 and 1 (each within the scatter of the next); then compound 3.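

Until now, changing the ring at this position, on a saturated chain carbon bound to a saturated ring carbon, had left the number in place. In this assay, 4-methylpiperazin-1-yl in place of piperidin-1-yl gives a 3.6-fold higher number from compound 2 to compound 3 (0.55 log units; beyond the scatter) and, in place of pyrrolidin-1-yl, it gives a 3.0-fold higher number from compound 1 to compound 3 (0.48 log units; beyond the scatter) and so inhibition is weaker with this group than with either of the other two rings, which stay within the scatter of each other. No measurement shown explains this loss of inhibition.

The compounds shown leave open whether the second ring nitrogen or the methyl group on it accounts for the step, a question that piperazin-1-yl without the methyl group or morpholin-4-yl could help to separate. They also leave open how an open-chain amine such as dimethylamino would compare with these rings.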